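A few compounds are considered here, and "the series" means these few. Any claim that something is new, unique, unknown or untested is made for them only; others in the source may bear on it.

Measured in an assay on membranes from HeLa cells for displacement of a labelled ligand from adenosine receptor A3 (Homo sapiens), read by scintillation counting, with a stated time of 180 min, tested at 1 uM; on this read-out lower numbers stand for less inhibition and higher numbers for more inhibition at the one concentration tested (going by the name of the read-out):
compound 1 `CC1=C(C(=O)OCC(C)C)C(c2ccoc2)NC(=O)N1`, 16%
compound 2 `CCCC(=O)C1=C(C)NC(=O)NC1c1ccoc1`, 2%
compound 3 `CCNC(=O)C1=C(C)NC(=O)NC1c1ccoc1`, 1%

Compound 3 stands below compound 1 by a number 15 percentage points lower from compound 1 to compound 3 (beyond the scatter), a step beyond the scatter, while its value and that of compound 2 differ only by a number 1 percentage points lower from compound 2 to compound 3 (within the scatter), which lies within the scatter. Compound 4 `CC1=C(C(=O)NC(C)C)C(c2ccoc2)NC(=O)N1` differs from compound 3 by methyl in place of hydrogen on a saturated chain carbon bound to an amide-type nitrogen and a saturated chain carbon. Within the data shown here, none of the measured steps touches that chain: a number 14 percentage points lower from compound 1 to compound 2 (beyond the scatter) and a number 15 percentage points lower from compound 1 to compound 3 (beyond the scatter) both replace the isobutoxy on a carbonyl carbon, and a number 1 percentage points lower from compound 2 to compound 3 (within the scatter) stayed within the scatter. Among the measured compounds shown here, with no step bearing directly on this change, compound 4 is expected to stay close to compound 3, a shift of a number 2 percentage points higher from compound 3 to compound 4 (within the scatter) and nothing beyond the scatter. Compound 4 is therefore estimated at 3%, between 0% and 12%.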

Compound 4, a percentage reported as inhibition, at one concentration (the size of the read-out at that concentration, not a potency): 3%
Estimate against measurement, compound 4: no gap at the digits printed, within the range that was stated.
By their numbers in this assay, from the lowest: compounds 3, 2 and 4 (each within the scatter of the next); then compound 1.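

On the ethylamino group, methyl in place of hydrogen gives a number 2 percentage points higher from compound 3 to compound 4 (within the scatter) in this assay and so leaves the read-out at this carbon effectively unmoved. Isopropylamino in place of propyl on the carbonyl carbon gives a number 1 percentage points higher from compound 2 to compound 4 (within the scatter) while isopropylamino in place of isobutoxy gives a number 13 percentage points lower from compound 1 to compound 4 (beyond the scatter) so the gap to the isobutoxy compound seen with ethylamino persists with isopropylamino.

As far as these compounds go, whether a longer chain on the amide-type nitrogen, or a cyclic amine such as piperidine on that carbonyl carbon, would reach the level of compound 1 stays open. No evidence at hand gives a reason for any of these numbers.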